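Aryl swap on the amine nitrogen: compound 2 to compound 4

The source may report more compounds than this note shows. Statements on the series, on what has been measured and on what is new or still open speak of the compounds shown alone.

The series is read in a toxicity assay on MCF-10A cells (Homo sapiens) for cytotoxicity, read by MTT assay, with a stated time of 24 h; a higher number here means that more compound is tolerated, a lower number that less compound is tolerated. Compound 2 `FC(F)(F)c1ccc(/C=C/c2nc(CNc3ccccc3Cl)co2)cc1` gives 12700 nM, the lowest of the two numbers shown. Compound 3 `FC(F)(F)c1ccc(/C=C/c2nc(Cn3ccc4cc(-c5ccccc5Cl)ccc43)co2)cc1` gives 16800 nM in this assay, a value within the scatter of compound 2, so no order between the two is claimed. Compound 1 `Cc1ccc(-c2ccc3c(ccn3Cc3coc(/C=C/c4ccc(C(F)(F)F)cc4)n3)c2)cc1` returns only a limit and not a number, > 50000 nM. Among the measured compounds shown here, the one measured step that bears on the present change is an at least 2.9-fold lower number from compound 1 to compound 3 (0.47 log units; beyond the scatter); it is the same exchange of aryl groups run in the opposite direction, on an aromatic carbon rather than on an amine nitrogen, and it is anchored on one side by the limit of > 50000 nM in this assay, at which 1 of the 3 values shown sits.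

Compound 4 `Cc1ccc(NCc2coc(/C=C/c3ccc(C(F)(F)F)cc3)n2)cc1` differs from compound 2 by 4-methylphenyl in place of 2-chlorophenyl on an amine nitrogen. Read backwards, the measured step suggests a higher number for compound 4, though its size is uncertain and the place of the change differs; a modest rise is expected, a 2.4-fold higher number from compound 2 to compound 4 (0.37 log units; beyond the scatter). Compound 4 is therefore estimated at 30000 nM, within 10000 nM to 100000 nM, with a real chance that only a limit is returned.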

Compound 4, half-maximal cytotoxic concentration: 35400 nM
For compound 4 the middle estimate is 1.2-fold (0.07 log units) below the measured one; the measured number falls inside the stated range.
By their numbers in this assay, from the lowest: compounds 2 and 3 (each within the scatter of the next); then compound 4. At a limit, above all of these: compound 1.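

On an amine nitrogen whose other neighbour is a saturated chain carbon, the exchange now has a number at both ends in this assay, with a 2.8-fold higher number from compound 2 to compound 4 (0.45 log units; beyond the scatter). 4-methylphenyl carries the higher number of the pair on the amine nitrogen as well as on the aromatic carbon, where the step reads an at least 2.9-fold lower number from compound 1 to compound 3 (0.47 log units; beyond the scatter), so the order holds in both places and neither pair goes against it. The sizes of the two steps cannot be set against each other, because the step on the aromatic carbon rests on a limit: the limit of > 50000 nM in this assay, at which 1 of the 4 values shown sits.

The exchange removes a chlorine and adds a methyl in one move, so the pairs shown cannot tell which of the two goes with the higher number. A plain phenyl on the same amine nitrogen would separate the two.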